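From a dimethylamino chain to a triazole diol

The source may hold more compounds than are shown below. What is called first, only, known or untested is meant among the compounds shown, and "the series" means these compounds.

Among the measured compounds shown here, in a functional assay on MCF7 cells (Homo sapiens) for cytotoxicity, read by MTT assay, with a stated time of 72 h (on this read-out higher numbers stand for weaker inhibition and lower numbers for stronger inhibition), compound 2 `CN(C)CCCCn1c2c(c3ccccc31)C(=O)c1c[n+]([O-])c3ccccc3c1C2=O` gives 220 nM, the lower of the two numbers so far, and compound 1 `O=C1c2c[n+]([O-])c3ccccc3c2C(=O)c2c1c1ccccc1n2CCCCN1CCNCC1` gives 12000 nM. Compound 3 `O=C1c2c[n+]([O-])c3ccccc3c2C(=O)c2c1c1ccccc1n2Cc1cn(C[C@@H](O)CO)nn1` remains unmeasured. Its change from compound 2 is 1-(2,3-dihydroxypropyl)-1H-1,2,3-triazol-4-yl in place of 3-(dimethylamino)propyl on a saturated chain carbon bound to an aromatic nitrogen. For the measured compounds named here, only one measured step bears on this: a 55-fold lower number from compound 1 to compound 2 (1.74 log units; beyond the scatter), large and beyond the scatter, with dimethylamino in place of piperazin-1-yl. Going by the values given here, that step shows a strong response to a change in the chain, but no measured compound carries a triazole, so the guide is indirect. The expected change is towards a higher number, estimated as an 11-fold higher number from compound 2 to compound 3 (1.06 log units; beyond the scatter). For compound 3 the estimate is 2500 nM, with an expected range of 400 nM to 12000 nM.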

Compound 3, half-maximal inhibitory concentration: 600 nM
Beside the measured number, compound 3's estimate is 4.2-fold (0.62 log units) above it, and the stated range covers the measured number.
By their numbers in this assay, from the lowest: compound 2; then compound 3; then compound 1.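

In this assay, the saturated chain carbon bound to an aromatic nitrogen accepts a group with no amine in it at only a moderate cost: a 2.7-fold higher number from compound 2 to compound 3 (0.44 log units; beyond the scatter), a much smaller shift than the large change seen between the two amine chains. The same group also compares well with the piperazine-bearing chain, with a 20-fold lower number from compound 1 to compound 3 (1.30 log units; beyond the scatter), so among these three compounds, the presence of an amine does not by itself set the number, as compound 1 shows. The data offer no measured basis for explaining either step.

The compounds shown leave open how the triazole ring and the diol each contribute, since both enter together. Also unresolved are the opposite configuration of the diol and a triazole bearing a simple methyl group or a carboxylic acid in place of the 2,3-dihydroxypropyl group.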